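Swapping the dichlorophenoxy group for a fluorophenoxy group

The source may report more compounds than this note shows. Statements on the series, on what has been measured and on what is new or still open speak of the compounds shown alone.

Compound 1 `Nc1cc(N)c2nc(-c3ccccc3)c(Oc3ccc(Cl)c(Cl)c3)nc2c1`: 52500 nM
Compound 2 `CCOC(=O)[C@H](CCC(=O)O)NC(=O)c1ccc(Sc2nc3cc(N)cc(N)c3nc2-c2ccccc2)cc1`: 44700 nM
Compound 3 `CCOC(=O)[C@H](CCC(=O)O)NC(=O)c1ccc(Oc2nc3cc(N)cc(N)c3nc2-c2ccccc2)cc1`: < 100000 nM

Three compounds sharing one core were tested in a functional assay on SF-268 cells (Homo sapiens) for inhibition, read by sulforhodamine B assay, with a stated time of 48 h; a lower number here means a stronger inhibitor of growth, a higher number a weaker inhibitor of growth. Compound 1 gives 52500 nM and compound 2 gives 44700 nM. Of these two numbers, that of compound 1 is the higher, but the gap to compound 2 falls within the usual scatter of this assay, so the two cannot be told apart. For compound 3 the result is only a limit of the assay, < 100000 nM, and not a number (the limit of < 100000 nM in this assay, at which 1 of the 3 values shown sits).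

Compound 4 `Nc1cc(N)c2nc(-c3ccccc3)c(Oc3ccc(F)cc3)nc2c1` is not yet measured. It differs from compound 1 in one place: 4-fluorophenyl in place of 3,4-dichlorophenyl on an oxygen on an aromatic ring. Among the compounds with values here, no measured pair shows a change of this kind, so no step can be read off the data. The step of a 1.1-fold higher number from compound 1 to compound 4 (0.06 log units; within the scatter) is expected to be small, not beyond the scatter, with no clear direction. Compound 4 is therefore expected to give about 60000 nM, with a likely span from 20000 nM to 150000 nM.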

Compound 4, concentration for total growth inhibition: 47900 nM
For compound 4 the middle estimate is 1.3-fold (0.10 log units) above the measured one; measured number inside the range.
By their numbers in this assay, from the lowest: compounds 2, 4 and 1 (each within the scatter of the next).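

In this assay, within the data shown here, the exchange on the oxygen gives a 1.1-fold lower number from compound 1 to compound 4 (0.04 log units; within the scatter) and is the first step that can be read at this position, since no earlier pair differed in one place. With 4-fluorophenyl in place of 3,4-dichlorophenyl, compound 1 and compound 4 cannot be told apart, so this exchange of one halogen-bearing phenyl for another leaves no mark that this assay can resolve. Nothing measured here bears on why the step is so small.

Both groups on this oxygen are phenyl rings carrying halogen, so one exchange says little about the position as a whole. On these data alone, it stays open whether an amine, a carboxylic acid or a longer chain in this place would give a step beyond the scatter.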